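The compounds below may be only part of what the source reports. "The series", "measured", "known", "first", "only" and "open" are said of these compounds alone.

Measured compounds and their values in a functional assay on HepG2 cells (Homo sapiens) for inhibition, with a stated time of 72 h; on this read-out lower numbers stand for stronger inhibition and higher numbers for weaker inhibition:
compound 1 `O=C(Nc1ccc(Cl)cc1)Nc1nc(Sc2c[nH]c3ccccc23)cc(N2CCCC2)n1`: 7870 nM
compound 2 `O=C(Nc1ccccc1)Nc1nc(Sc2c[nH]c3ccccc23)cc(N2CCCC2)n1`: 11400 nM
compound 3 `O=C(Nc1ccccc1)Nc1nc(Nc2ccccc2)cc(Sc2c[nH]c3ccccc23)n1`: 14400 nM

All three numbers lie within the scatter of one another, so no order among them is claimed. Compound 2 and compound 3 differ in their cores by anilino in place of pyrrolidin-1-yl on an aromatic carbon; the step is a 1.3-fold higher number from compound 2 to compound 3 (0.10 log units; within the scatter). Compound 1 differs from compound 2 by chloro in place of hydrogen on an aromatic carbon; the step is a 1.4-fold lower number from compound 2 to compound 1 (0.16 log units; within the scatter).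

Compound 4 `O=C(Nc1ccccc1)Nc1nc(Nc2ccc(Cl)cc2)cc(Sc2c[nH]c3ccccc23)n1` has not yet been measured. It differs from compound 3 by chloro in place of hydrogen on an aromatic carbon. This is the same change as that from compound 2 to compound 1, at a place described in the same words; the two instances differ only in the wider reading, which for compound 1 is phenylcarbamoyl to (4-chlorophenyl)carbamoyl and for compound 4 is anilino to (4-chlorophenyl)amino, and in the core that carries it, which differs as anilino in place of pyrrolidin-1-yl on an aromatic carbon. With one earlier instance only, the expectation rests on it: because a 1.4-fold lower number from compound 2 to compound 1 (0.16 log units; within the scatter) stayed within the scatter, the step from compound 3 to compound 4 is expected to be of similar small size, a 1.4-fold lower number from compound 3 to compound 4 (0.14 log units; within the scatter). Compound 4 is therefore estimated at 10500 nM in this assay. For compound 4 the expected range runs from 4500 nM to 25000 nM.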

Compound 4, half-maximal inhibitory concentration: 12600 nM
Compound 4: middle estimate off by 1.2-fold (0.08 log units), on the low side; the range from low to high includes it.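

In this assay, chloro in place of hydrogen on an aromatic carbon gives a 1.1-fold lower number from compound 3 to compound 4 (0.06 log units; within the scatter), and the two instances of this change do not differ: the same change on two cores in this assay, a 1.4-fold lower number (0.16 log units; within the scatter) from compound 2 to compound 1 and a 1.1-fold lower number (0.06 log units; within the scatter) from compound 3 to compound 4, 1.3-fold (0.10 log units) apart, within the scatter of two such steps

The change therefore carries from the core of compound 2 to the core of compound 3 as a step that stays inside the scatter on both, and the cross-core comparison a 1.1-fold higher number from compound 2 to compound 4 (0.04 log units; within the scatter) is of the same small size, with (4-chlorophenyl)amino in place of pyrrolidin-1-yl. This does not show that chloro has any real effect on the number here, nor does it give a direction for the change: the agreement is between two small steps, on two cores only, and the chloro sits on a phenylcarbamoyl group in one instance and on an anilino group in the other, so it supports no rule for other cores or other places.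

The compounds shown leave open whether any substituent on these phenyl rings other than chloro, such as a carboxylic acid or a primary amine, would produce a step beyond the scatter. They also leave open what a longer alkyl chain in place of pyrrolidin-1-yl or anilino on the shared core would do to the number.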